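Trading a tert-butoxycarbonyl for a methyl: solubility outlook

The compounds below may be only part of what the source reports. "The series", "measured", "known", "first", "only" and "open" are said of these compounds alone.

Compound 1, `O=C(CN1CCNCC1)N1CCC(NS(=O)(=O)c2cc(S(=O)(=O)c3ccccc3)ccc2C(F)(F)F)CC1`: in a physicochemical assay for solubility (on this read-out higher numbers stand for higher solubility and lower numbers for lower solubility), compound 1 gives 50000 nM.
Compound 2, `CC(C)(C)OC(=O)N1CCC[C@@H]1C(=O)N1CCC(NS(=O)(=O)c2cc(S(=O)(=O)c3ccccc3)ccc2C(F)(F)F)CC1`: in this assay compound 2 gives 25000 nM.
Compound 3, `CCNC(=O)N1CCC[C@H]1C(=O)N1CCC(NS(=O)(=O)c2cc(S(=O)(=O)c3ccccc3)ccc2C(F)(F)F)CC1`: in this assay compound 3 gives 100000 nM.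

Compound 2 has the lowest of the three numbers; one step, a 2.0-fold lower number from compound 1 to compound 2 (0.30 log units; within the scatter), lies within the scatter, while the other, a 4.0-fold higher number from compound 2 to compound 3 (0.60 log units; beyond the scatter), goes beyond it.

Compound 4, `CN1CCC[C@H]1C(=O)N1CCC(NS(=O)(=O)c2cc(S(=O)(=O)c3ccccc3)ccc2C(F)(F)F)CC1`, differs from compound 2 in one place: 1-methylpyrrolidin-2-yl in place of 1-(tert-butoxycarbonyl)pyrrolidin-2-yl on a carbonyl carbon. The step that bears on this is a 4.0-fold higher number from compound 2 to compound 3 (0.60 log units; beyond the scatter), where the same group left and a different, smaller one entered with a modest rise; the group leaving here is the one shared by the lowest compound. A modest upward step is therefore expected for compound 4, a 4.0-fold higher number from compound 2 to compound 4 (0.60 log units; beyond the scatter). Compound 4 is estimated at 100000 nM, within a range from 40000 nM to 250000 nM.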

Compound 4, solubility: 100000 nM
The estimate for compound 4 equals the measured number at the digits printed, and the stated range covers the measured number.
By their numbers in this assay, from the lowest: compounds 2, 1, 3 and 4 (each within the scatter of the next, the first and the last beyond it).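

In this assay, replacing 1-(tert-butoxycarbonyl)pyrrolidin-2-yl with the smaller 1-methylpyrrolidin-2-yl gives a 4.0-fold higher number from compound 2 to compound 4 (0.60 log units; beyond the scatter) and so shows a second group on the ring nitrogen that stands above compound 2. Methyl and ethylcarbamoyl on that nitrogen cannot be told apart, with no change at the digits printed from compound 3 to compound 4 (within the scatter) as the step between them. The step to the open-chain piperazine compound is also small, with a 2.0-fold higher number from compound 1 to compound 4 (0.30 log units; within the scatter) leaving those two unranked.

As far as these compounds go, whether a carboxylic acid or a longer alkyl chain on that ring nitrogen would behave the same remains open. Nothing available here gives a measured reason for these steps.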